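Chloro in place of methoxy: expected step to compound 4

The compounds below may be only part of what the source reports. "The series", "measured", "known", "first", "only" and "open" are said of these compounds alone.

Of the compounds shown here, three sharing one core have been measured in a functional assay on the whole organism (strain Kunming) with Mus musculus as the target, with a stated time of 0.5 h; on this read-out higher numbers stand for an effect only at larger amounts of compound and lower numbers for an effect already at smaller amounts. Compound 1 `COc1cc(OC)c(OC)cc1/C=C/COC(=O)/C=C/c1ccc(Br)cc1`, with a 4-bromophenyl, gives 446 umol/kg. Compound 2 `COc1cccc(/C=C/C(=O)OC/C=C/c2cc(OC)c(OC)cc2OC)c1`, with a 3-methoxyphenyl, gives 643 umol/kg. Compound 3 `COc1ccc(/C=C/C(=O)OC/C=C/c2cc(OC)c(OC)cc2OC)cc1`, with a 4-methoxyphenyl, gives 634 umol/kg. Compound 3 therefore lies within the scatter of both other compounds, and no order can be read among the three.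

Compound 4 `COc1cc(OC)c(OC)cc1/C=C/COC(=O)/C=C/c1ccc(Cl)cc1` has chloro in place of methoxy on an aromatic carbon, para to a large group: chloro in place of methoxy on an aromatic carbon. The same difference reads 4-methoxyphenyl to 4-chlorophenyl.

The closest measured change, methoxy in place of bromo on an aromatic carbon, shows a 1.4-fold higher number from compound 1 to compound 3 (0.15 log units; within the scatter). The other two steps show a 1.4-fold higher number from compound 1 to compound 2 (0.16 log units; within the scatter) and a 1.0-fold lower number from compound 2 to compound 3 (0.01 log units; within the scatter). Going by the values given here, all three stay within the scatter, although no chloro compound has yet been measured and the series holds only three values. No step beyond the scatter is therefore expected in this assay, and no firm direction can be assigned.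

The expected step is a 1.3-fold lower number from compound 3 to compound 4 (0.10 log units; within the scatter), which is estimated to stay within the scatter. For compound 4 the estimated value is 500 umol/kg, with an expected range of 280 umol/kg to 850 umol/kg.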

Compound 4, dose for half-maximal effect: 364 umol/kg
For compound 4 the middle estimate is 1.4-fold (0.14 log units) above the measured one; the measured number falls inside the stated range.
By their numbers in this assay, from the lowest: compounds 4, 1, 3 and 2 (each within the scatter of the next).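

In this assay, chloro on an aromatic carbon, para to a large group, can now be read against both groups previously seen at that place: chloro in place of methoxy gives a step (a 1.7-fold lower number from compound 3 to compound 4 (0.24 log units; within the scatter)), and chloro in place of bromo gives another (a 1.2-fold lower number from compound 1 to compound 4 (0.09 log units; within the scatter)). The comparison with the other methoxy compound, 4-chlorophenyl in place of 3-methoxyphenyl, also stays inside the usual variation (a 1.8-fold lower number from compound 2 to compound 4 (0.25 log units; within the scatter)). Chloro, bromo and methoxy at this place, together with the 3-methoxyphenyl variant, therefore still give no readable order, and a second halogen adds no step beyond the scatter; no measurement bearing on the reason for these numbers is available.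

From the compounds shown here alone, whether this position is insensitive in general stays open, since the groups compared here are all small and uncharged, and an amine, a carboxylic acid or a longer chain at the same place could behave differently. Also open, going by these compounds, is how the read-out responds to changes elsewhere, such as replacing the ester with an amide or altering the methoxy groups on the other aromatic ring of the shared core.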